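The source may report more compounds than this note shows. Statements on the series, on what has been measured and on what is new or still open speak of the compounds shown alone.

Measured compounds and their values:
- Compound 1, `Cc1ccc(/C=C2\CN(C)C[C@@]3(C2=O)[C@@H](c2ccc(C)cc2)CN(C)[C@@]32C(=O)Nc3ccccc32)cc1`: 89.7%
- Compound 2, `Cc1ccc(/C=C2\CN(C)C[C@@]3(C2=O)[C@@H](c2ccc(C)cc2)CN(C)[C@@]32C(=O)N(C)c3ccccc32)cc1`: 122%
- Compound 3, `CN1C/C(=C\c2ccc(-c3cccs3)cc2)C(=O)[C@]2(C1)[C@@H](c1ccc(-c3cccs3)cc1)CN(C)[C@@]21C(=O)Nc2ccccc21`: 126%

All three were tested in a functional assay on the whole organism (strain Wister albino) for inhibition, with Rattus norvegicus as the target, read by paw edema, with stated times of 1 h and 4 h, at a dose of 50 mg/kg by the intraperitoneal route; on this read-out lower numbers stand for less inhibition and higher numbers for more inhibition at the one dose given (going by the name of the read-out). Compound 1 and compound 2 share one core, and compound 3 carries a different one; how the two cores differ is not broken down here. Compound 1 and compound 2 differ in a single place, (methyl in place of hydrogen on an amide-type nitrogen in a ring). That change gave a number 32.3 percentage points higher from compound 1 to compound 2 (beyond the scatter). Compound 3 has the highest number of the three, but compound 2 stands within the usual scatter of it, so the two cannot be ranked against each other; only compound 1 lies clearly lower than compound 3.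

Compound 4, `CN1C/C(=C\c2ccc(-c3cccs3)cc2)C(=O)[C@]2(C1)[C@@H](c1ccc(-c3cccs3)cc1)CN(C)[C@@]21C(=O)N(C)c2ccccc21`, has not yet been measured in this assay. Within the data shown here, it differs from compound 3 in one place, (methyl in place of hydrogen on an amide-type nitrogen in a ring), which is the same change as the one from compound 1 to compound 2, at the same kind of position in the core. On the core of compound 1 this change raised inhibition by a large step, beyond the scatter. If it acts alike on the core of compound 3, a rise of similar size is expected from compound 3 to compound 4, and the expected step is a number 22 percentage points higher from compound 3 to compound 4 (beyond the scatter). That expectation rests on a single pair only, so it is uncertain. For compound 4 the estimate in this assay is 148%, with a range from 118% to 175%.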

Compound 4, a percentage reported as inhibition, in the whole organism at one dose (the size of the read-out at that dose, not a potency): 124%
Compound 4: the middle estimate sits 24 percentage points above what was measured; low and high end bracket the measured number.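

In this assay, methyl in place of hydrogen on the amide-type nitrogen gives a number 2 percentage points lower from compound 3 to compound 4 (within the scatter), so on this core the change has no effect that can be told apart from the usual scatter. Set beside the earlier pair, the same change does not carry over with the same size from one core to the other: the same change on two cores in this assay, a number 32.3 percentage points higher (beyond the scatter) from compound 1 to compound 2 and a number 2 percentage points lower (within the scatter) from compound 3 to compound 4, 34.3 percentage points apart, beyond the scatter of two such steps This shows that the large gain seen on the core of compound 1 cannot simply be assumed on another core in this series, but with only one pair on each core it does not show why the two differ or how the change would behave on any further core.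

The compounds shown leave open whether a longer chain such as ethyl on the same nitrogen would follow the methyl on either core. They also leave open which part of the difference between the two cores decides the size of the step, and whether the pattern would hold on a third core bearing a group such as an amine or a carboxylic acid.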